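A few compounds are considered here, and "the series" means these few. Any claim that something is new, unique, unknown or untested is made for them only; others in the source may bear on it.

Among the compounds with values here, in a functional assay on THP-1 cells (Homo sapiens) for inhibition, read by sulforhodamine B assay, with a stated time of 48 h, tested at 50 uM (on this read-out lower numbers stand for less inhibition of growth and higher numbers for more inhibition of growth at the one concentration tested), compound 3 (`COc1cc(/C=C/C(=O)/C=C/c2ccccc2)ccc1OCc1cn(CCCCCOc2cc(=O)oc3ccccc23)nn1`) gives 26%, the lowest number so far, while compound 2 (`COc1ccccc1/C=C/C(=O)/C=C/c1ccc(OCc2cn(CCCCCOc3cc(=O)oc4ccccc34)nn2)c(OC)c1`) gives 37% and compound 1 (`COc1ccc(/C=C/C(=O)/C=C/c2ccc(OCc3cn(CCCCCOc4cc(=O)oc5ccccc45)nn3)c(OC)c2)cc1OC`) gives 47%. Compound 4 (`COc1cc(/C=C/C(=O)/C=C/c2cc(OC)c(OC)c(OC)c2)ccc1OCc1cn(CCCCCOc2cc(=O)oc3ccccc23)nn1`) has 3,4,5-trimethoxyphenyl in place of the phenyl of compound 3, on a double-bonded chain carbon bound to a double-bonded chain carbon: 3,4,5-trimethoxyphenyl in place of phenyl on a double-bonded chain carbon bound to a double-bonded chain carbon. Two modest measured steps, read in reverse, bear on this change: a number 21 percentage points lower from compound 1 to compound 3 (beyond the scatter) and a number 11 percentage points lower from compound 2 to compound 3 (beyond the scatter). A third, a number 10 percentage points lower from compound 1 to compound 2 (within the scatter), lies within the scatter, so adding further methoxy groups need not add more. A modest upward step is therefore expected in this assay, estimated as a number 19 percentage points higher from compound 3 to compound 4 (beyond the scatter). Compound 4 is estimated at 45%, with an expected range of 30% to 60%.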

Compound 4, percent growth inhibition at one concentration: 55%
Compound 4: middle estimate off by 10 percentage points, on the low side; the measured number falls inside the stated range.
By their numbers in this assay, from the lowest: compound 3; then compounds 2, 1 and 4 (each within the scatter of the next, the first and the last beyond it).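

Within the data shown here, replacing phenyl with 3,4,5-trimethoxyphenyl at this place gives the largest step so far, a number 29 percentage points higher from compound 3 to compound 4 (beyond the scatter), and replacing 2-methoxyphenyl with it also counts, a number 18 percentage points higher from compound 2 to compound 4 (beyond the scatter). Going from 3,4-dimethoxyphenyl to 3,4,5-trimethoxyphenyl gives a number 8 percentage points higher from compound 1 to compound 4 (within the scatter), so this further methoxy shows no clear gain. Swapping methoxy for hydrogen on an aromatic carbon now reads alike on two cores: the same change on two cores in this assay, a number 11 percentage points lower (beyond the scatter) from compound 2 to compound 3 and a number 8 percentage points lower (within the scatter) from compound 4 to compound 1, 3 percentage points apart, within the scatter of two such steps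

On these data alone, whether methoxy itself is needed stays open, since no ring here carries a hydroxy group, an amine or a carboxylic acid instead. As far as these compounds go, whether a longer ether such as ethoxy would serve equally also stays open.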